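A few compounds are considered here, and "the series" means these few. Any claim that something is new, unique, unknown or untested is made for them only; others in the source may bear on it.

Working notes on the series

Three compounds of a shared core have been run in a functional assay on the whole organism (artery, strain albino) with Rattus norvegicus as the target, with a stated time of 240 min, at a dose of 10 mg/kg by the oral route; a lower number here means less inhibition, a higher number more inhibition at the dose given (going by the name of the read-out). Compound 1 `CC1=C(C(=O)Nc2ccc(Br)cc2)C(c2ccc(Cl)cc2Cl)N=C(SCc2ccccc2Cl)N1` gives 28.7% in this assay. Compound 2 `CC1=C(C(=O)Nc2ccc(Br)cc2)C(c2ccc(Cl)cc2Cl)N=C(SCc2cccc(Cl)c2)N1` gives 15.9%, and compound 3 `COc1ccc(C2N=C(SCc3ccccc3Cl)NC(C)=C2C(=O)Nc2ccc(Br)cc2)cc1` gives 15.4%. The values of compound 2 and compound 3 lie within the scatter of each other, so nothing separates them.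

Compound 2 differs from compound 1 by 3-chlorophenyl in place of 2-chlorophenyl on a saturated chain carbon bound to a sulfur, and this change made a step of a number 12.8 percentage points lower from compound 1 to compound 2 (beyond the scatter). Compound 3 differs from compound 1 by 4-methoxyphenyl in place of 2,4-dichlorophenyl on a saturated ring carbon, with a step of a number 13.3 percentage points lower from compound 1 to compound 3 (beyond the scatter).

Compound 4 `COc1ccc(C2N=C(SCc3cccc(Cl)c3)NC(C)=C2C(=O)Nc2ccc(Br)cc2)cc1` has not yet been run in this assay. It differs from compound 3 by 3-chlorophenyl in place of 2-chlorophenyl on a saturated chain carbon bound to a sulfur. This is the same change as that from compound 1 to compound 2, at the same place, made here on the core of compound 3 rather than the core of compound 1; the two cores differ by the change described above from compound 1 to compound 3.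

The expectation for compound 4 rests on one earlier step only. Because the same change gave a number 12.8 percentage points lower from compound 1 to compound 2 (beyond the scatter), a step of about a number 9.4 percentage points lower from compound 3 to compound 4 (within the scatter) from compound 3 to compound 4 is expected in this assay, though from a starting value already low the step may be cut short. Compound 4 is therefore estimated at 6% in this assay, with a range from -5% to 17%.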

Compound 4, a percentage reported as inhibition, in the whole organism at one dose (the size of the read-out at that dose, not a potency): 33.8%
Beside the measured number, compound 4's estimate is 27.8 percentage points below it, outside the stated range (above it).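

In this assay, 3-chlorophenyl in place of 2-chlorophenyl on a saturated chain carbon bound to a sulfur gives a step of a number 18.4 percentage points higher from compound 3 to compound 4 (beyond the scatter), so this change did not carry over from the core of compound 1 to the core of compound 3 and instead reversed direction: the same change on two cores in this assay, a number 12.8 percentage points lower (beyond the scatter) from compound 1 to compound 2 and a number 18.4 percentage points higher (beyond the scatter) from compound 3 to compound 4, 31.2 percentage points apart, beyond the scatter of two such steps

The other change behaves in the same way, with 4-methoxyphenyl in place of 2,4-dichlorophenyl on a saturated ring carbon giving a step of a number 17.9 percentage points higher from compound 2 to compound 4 (beyond the scatter), again opposite in direction to the earlier step: the same change on two cores in this assay, a number 13.3 percentage points lower (beyond the scatter) from compound 1 to compound 3 and a number 17.9 percentage points higher (beyond the scatter) from compound 2 to compound 4, 31.2 percentage points apart, beyond the scatter of two such steps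

Across these four compounds, the result of either change therefore depends on the group present at the other place, so neither step can be carried to a new core as a fixed increment, but the data do not show why this happens or whether it extends to any compound beyond these four.

The compounds shown leave open whether the reversal persists when an unsubstituted phenyl, or a phenyl bearing an amine or a carboxylic acid, stands on the saturated chain carbon bound to a sulfur. They also leave open whether the same pattern would appear at other doses or times, since each value is a single-dose read-out rather than a potency.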